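From 4-chlorophenyl to 3-chlorophenyl in a small series

The source may report more compounds than this note shows. Statements on the series, on what has been measured and on what is new or still open speak of the compounds shown alone.

Three related compounds have been measured so far in a functional assay on PC-3 cells (Homo sapiens) for inhibition, read by MTT assay, with a stated time of 48 h, tested at 10 uM; on this read-out lower numbers stand for less inhibition of growth and higher numbers for more inhibition of growth at the one concentration tested. In this test, compound 1 `Cc1oc2c([C@H]3CCN(C)C[C@H]3O)c(O)cc(O)c2c(=O)c1C(O)c1cccc(Cl)c1` gives 31%, compound 2 `CN1CC[C@H](c2c(O)cc(O)c3c(=O)cc(/C=C/c4ccccc4)oc23)[C@H](O)C1` gives 10% and compound 3 `CN1CC[C@H](c2c(O)cc(O)c3c(=O)cc(/C=C/c4ccc(Cl)cc4)oc23)[C@H](O)C1` gives 12%. Compound 3 therefore lies well under compound 1, by more than the usual scatter, and cannot be told apart from compound 2.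

The next compound to be tested is compound 4 `CN1CC[C@H](c2c(O)cc(O)c3c(=O)cc(/C=C/c4cccc(Cl)c4)oc23)[C@H](O)C1`. Its structural change is small: 3-chlorophenyl in place of 4-chlorophenyl on a double-bonded chain carbon bound to a double-bonded chain carbon. The group sits on a double-bonded chain carbon bound to a double-bonded chain carbon, and the rest of the molecule stays the same.

Among the compounds with values here, only one measured step bears directly on this change: a number 2 percentage points higher from compound 2 to compound 3 (within the scatter). That step puts chloro in place of hydrogen on an aromatic carbon. Adding the chloro group made no difference beyond the scatter, but no measured pair shows what moving it does, so the evidence is thin. Compound 1 differs from compound 3 in more than one place and offers no clean comparison. No change beyond the scatter is expected, and the estimated step is a number 1 percentage points higher from compound 3 to compound 4 (within the scatter). Compound 4 is estimated to give 13%, within an expected range of 3% to 25%.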

Compound 4, percent growth inhibition at one concentration: 53%
Compound 4: the middle estimate sits 40 percentage points below what was measured, outside the stated range (above it).
By their numbers in this assay, from the lowest: compounds 2 and 3 (each within the scatter of the next); then compound 1; then compound 4.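

In this assay, within the data shown here, where the chloro group sits on the ring counts for far more than the earlier compounds could show: 3-chlorophenyl in place of 4-chlorophenyl, with the same atoms joined differently, gives a number 41 percentage points higher from compound 3 to compound 4 (beyond the scatter). Chloro in place of hydrogen on an aromatic carbon now has two very different outcomes: the 4-chlorophenyl compound gave a number 2 percentage points higher from compound 2 to compound 3 (within the scatter), while the 3-chlorophenyl compound gives a number 43 percentage points higher from compound 2 to compound 4 (beyond the scatter), so in this small set, what adding the chloro group does depends on where it is placed. Nothing in the data shown gives a reason for this gap between the two placements.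

The compounds shown leave open whether the gain belongs to chloro itself or to any group at that place, which a methoxy group or an amine in place of the chloro of the 3-chlorophenyl group could help to settle. On these data alone, each number here also comes from a single concentration, so how compound 4 behaves across a range of concentrations remains open.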